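Swapping the acid for a glycine ester amide

This account rests on a few compounds, and the source may have more. Where it says the series, first, only, none or still open, it means among the compounds named here.

Measured so far:
compound 1 `CC(C)(C)OC(=O)NCC#Cc1ccc2c(c1)C=C([N+](=O)[O-])C(C(F)(F)F)O2` gives 1200 nM
compound 2 `O=[N+]([O-])C1=Cc2cc(C#CC3CC3)ccc2OC1C(F)(F)F` gives 4870 nM
compound 3 `O=C(O)c1ccc(C#Cc2ccc3c(c2)C=C([N+](=O)[O-])C(C(F)(F)F)O3)cc1` gives 1090 nM

All three share one core and differ only in the group attached to the triple-bonded carbon. In a functional assay on 1321N1 cells for antagonist activity at P2Y purinoceptor 6 (Homo sapiens), read by fluorescence and calcium flux (on this read-out higher numbers stand for weaker inhibition and lower numbers for stronger inhibition), compound 3 and compound 1 sit close together, the step of a 1.1-fold lower number from compound 1 to compound 3 (0.04 log units; within the scatter) being within the scatter, while compound 2 stands apart: a 4.5-fold lower number from compound 2 to compound 3 (0.65 log units; beyond the scatter) and a 4.1-fold higher number from compound 1 to compound 2 (0.61 log units; beyond the scatter) are both modest but beyond the scatter. So the end group matters, yet two rather different end groups gave the same result.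

Compound 4 `COC(=O)CNC(=O)c1ccc(C#Cc2ccc3c(c2)C=C([N+](=O)[O-])C(C(F)(F)F)O3)cc1` has not yet been measured. It differs from compound 3 in one place: ((methoxycarbonyl)methyl)amino in place of hydroxy on a carbonyl carbon. The 4-carboxyphenyl attachment of compound 3 thus becomes a carboxamide carrying a further ester. The step of a 1.1-fold lower number from compound 1 to compound 3 (0.04 log units; within the scatter) shows that a group with a carbonyl and an amide hydrogen, as in compound 1, is tolerated as well as the acid. A step of about the same small size, a 1.4-fold higher number from compound 3 to compound 4 (0.14 log units; within the scatter), is therefore expected, with the number for compound 4 estimated at 1500 nM, in a range from 500 nM to 5000 nM.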

Compound 4, half-maximal inhibitory concentration: 6330 nM
Beside the measured number, compound 4's estimate is 4.2-fold (0.63 log units) below it, and the stated range ends below it.
By their numbers in this assay, from the lowest: compounds 3 and 1 (each within the scatter of the next); then compounds 2 and 4 (each within the scatter of the next).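

In this assay, turning the carboxy group into ((methoxycarbonyl)methyl)carbamoyl gives a 5.8-fold higher number from compound 3 to compound 4 (0.76 log units; beyond the scatter), a modest step but one beyond the scatter, so the outer end of the 4-carboxyphenyl group is not indifferent to change. Inhibition is weaker here, which shows that a carbonyl and an amide hydrogen in the added group are not enough on their own to hold the number seen for compound 3. No measurement here explains the loss.

The compounds shown leave open whether the loss follows from the amide link itself or from the chain ending in a methyl ester. A plain carboxamide, or the same chain ending in a carboxylic acid, would help separate these two parts of the change.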